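This account rests on a few compounds, and the source may have more. Where it says the series, first, only, none or still open, it means among the compounds named here.

Series notes, measured in an ADME assay on KB cells (Homo sapiens) for cytotoxicity, read by MTT assay, with a stated time of 72 h; on this read-out higher numbers stand for weaker inhibition and lower numbers for stronger inhibition:

- compound 1 `COc1ccc(C2=C(c3cc(OC)c(OC)c(OC)c3)C(=O)C(OC(C)=O)C2)cc1OC(C)C`: > 100 ug/mL (a limit)
- compound 2 `COc1ccc(C2=C(c3cc(OC)c(OC)c(OC)c3)C(=O)C(O[SiH2]C(C)(C)C)C2)cc1OC(C)C`: 7.5 ug/mL
- compound 3 `COc1ccc(C2=C(c3cc(OC)c(OC)c(OC)c3)C(=O)CC2O)cc1O`: < 1 ug/mL (a limit)

Compound 1 has no number, only a limit: it stands at the limit of > 100 ug/mL in this assay, at which 1 of the 3 values shown sits. Compound 3 is also known only as a limit, at the limit of < 1 ug/mL in this assay, at which 1 of the 3 values shown sits.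

The next analogue is compound 4 `COc1ccc(C2=C(c3cc(OC)c(OC)c(OC)c3)C(=O)C(OC(C)=O)C2)cc1Cl`, which keeps the acetate of compound 1 and changes the aromatic substituent: chloro in place of isopropoxy on an aromatic carbon. This is chloro in place of isopropoxy on an aromatic carbon, ortho to a methoxy group and meta to a large group.

Within the data shown here, the one measured step, an at least 13-fold lower number from compound 1 to compound 2 (1.12 log units; beyond the scatter), is large, but it concerns the group on an oxygen on a saturated carbon, not this aromatic carbon. It therefore gives no direct size for the present change. Compound 3 differs from compound 1 in more than one place and isolates nothing here. With so little to go on, only a modest shift in this assay toward lower numbers is expected, and a further limit is quite possible.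

The expected step is an at least 2.0-fold lower number from compound 1 to compound 4 (0.30 log units; that floor lies within the scatter), and it may not leave the scatter.

For compound 4 the estimated value is 50 ug/mL, with an expected range of 8 ug/mL to 150 ug/mL.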

Compound 4, half-maximal inhibitory concentration: 64 ug/mL
For compound 4 the middle estimate is 1.3-fold (0.11 log units) below the measured one; the range from low to high includes it.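

In this assay, the aromatic carbon ortho to a methoxy group and meta to a large group now has a first reading: with the acetate kept, chloro in place of isopropoxy gives an at least 1.5-fold lower number from compound 1 to compound 4 (0.19 log units; that floor lies within the scatter). Compound 1 is known only as a limit: the limit of > 100 ug/mL in this assay, at which 1 of the 4 values shown sits. The step therefore fixes only a floor and no true size. Compound 4, at 64 ug/mL, gives the acetate pair a measured number that later changes on this aromatic carbon can be read against.

Whether chloro in place of isopropoxy would have the same effect with the silicon-bearing group of compound 2 on the oxygen on a saturated carbon remains open, since no pair shown isolates that combination. Going by these compounds, it is also open whether an amine, a bromo or a longer alkoxy chain such as butoxy on this aromatic carbon would move the number beyond the scatter, in either direction, from compound 4.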